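Lengthening the small alkyl group on a pyrazole-based hydroxamic acid

The source may hold more compounds than are shown below. What is called first, only, known or untested is meant among the compounds shown, and "the series" means these compounds.

Compound 1 `Cc1cc(-c2ccc(F)cc2)n(Cc2ccc(C(=O)NO)cc2)n1` stands lowest of the three compounds measured in an assay on cells for inhibition of protein deacetylase HDAC6 (Homo sapiens), read by fluorescence, with stated times of 15 min and 60 min (a higher number here means a weaker inhibitor, a lower number a stronger inhibitor), where compound 1 gives 20 nM. Compound 2 `Cc1ccc(-c2cc(C)nn2Cc2ccc(C(=O)NO)cc2)cc1` gives 29 nM, and the step of a 1.5-fold higher number from compound 1 to compound 2 (0.16 log units; within the scatter) lies within the scatter. Compound 3 `CCCc1cc(-c2ccc(F)cc2)nn1Cc1ccc(C(=O)NO)cc1` gives 107 nM, a clearly higher number, but compound 3 differs from compound 1 in more than one place, so that gap is not a single step. Compound 4 `CCc1cc(-c2ccc(F)cc2)n(Cc2ccc(C(=O)NO)cc2)n1` carries the change methyl in place of hydrogen on a saturated chain carbon bound to an aromatic carbon relative to compound 1. Going by the values given here, no measured step bears directly on this change; the only single step here, from fluoro to methyl, stayed within the scatter. Compound 4 is therefore expected to move little, a 1.5-fold higher number from compound 1 to compound 4 (0.18 log units; within the scatter), with an estimate of 30 nM in this assay, ranging from 12 nM to 80 nM.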

Compound 4, half-maximal inhibitory concentration: 69 nM
For compound 4 the middle estimate is 2.3-fold (0.36 log units) below the measured one, and the stated range covers the measured number.
By their numbers in this assay, from the lowest: compounds 1 and 2 (each within the scatter of the next); then compounds 4 and 3 (each within the scatter of the next).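

Going from methyl to ethyl on this saturated chain carbon bound to an aromatic carbon weakens inhibition in this assay: the change brings a 3.5-fold higher number from compound 1 to compound 4 (0.54 log units; beyond the scatter). So this place responds to the addition of one carbon, a sensitivity that the fluoro to methyl step did not reveal, since that step stayed within the scatter. Nothing available here explains the weakening. Going by these compounds, it remains open how a longer chain, or an amine, would fare in this place on the core of compound 1. Compound 3 cannot settle this, as it differs from compound 1 in more than one place.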